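Methoxy in place of hydrogen on a hydroxynaphthalene biaryl

The source may hold more compounds than are shown below. What is called first, only, known or untested is meant among the compounds shown, and "the series" means these compounds.

Of the compounds shown here, two have been measured so far in an assay for binding affinity to 17-beta-hydroxysteroid dehydrogenase type 2 (Homo sapiens), with a stated time of 20 min, tested at 1 uM; a lower number here means less inhibition, a higher number more inhibition at the concentration tested (going by the name of the read-out). Compound 1 `Oc1cccc2cc(-c3ccccc3)ccc12` gives 20% in this assay, the lowest of the two numbers shown. Among the measured compounds shown here, compound 2 `Oc1cccc(-c2ccc3c(O)cccc3c2)c1` gives 32% in this assay, and the single measured step, hydroxy in place of hydrogen on an aromatic carbon, is a number 12 percentage points higher from compound 1 to compound 2 (beyond the scatter).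

Compound 3 `COc1ccc(-c2ccc3c(O)cccc3c2)cc1` has not yet been measured. It differs from compound 1 by methoxy in place of hydrogen on an aromatic carbon, the change sitting para to a large group. For the measured compounds named here, the only step that bears on it is the one from compound 1 to compound 2, where a hydroxy group entering at this kind of position raised the number modestly. Methoxy brings one acceptor but no donor, so a smaller rise, or none beyond the scatter, is expected. For compound 3 the estimate in this assay is 26%, with a range of 12% to 40%, which means an expected step of a number 6 percentage points higher from compound 1 to compound 3 (within the scatter).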

Compound 3, a percentage reported as inhibition, at one concentration (the size of the read-out at that concentration, not a potency): 20%
Beside the measured number, compound 3's estimate is 6 percentage points above it; low and high end bracket the measured number.
By their numbers in this assay, from the lowest: compounds 1 and 3 (each within the scatter of the next); then compound 2.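

In this assay, placing methoxy on an aromatic carbon para to a large group gives no change at the digits printed from compound 1 to compound 3 (within the scatter) and so shows no shift that can be told from the scatter at this position. The earlier hydroxy change gave a number 12 percentage points higher from compound 1 to compound 2 (beyond the scatter) and remains the only step shown here that lies beyond the scatter, so a rise does not follow from every oxygen-bearing group added to the core of compound 1, with compound 2 the one compound that shows a rise. Nothing shown here offers an explanation for this result.

From the compounds shown here alone, it remains open whether hydroxy in this same place would give a number like that of compound 2. Going by these compounds, the effect of an amine, a carboxylic acid or a longer alkoxy chain in this place also remains open.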